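From a small amine to a larger group

The source may hold more compounds than are shown below. What is called first, only, known or untested is meant among the compounds shown, and "the series" means these compounds.

Measured in a functional assay (aorta) with Rattus norvegicus as the target; on this read-out lower numbers stand for an effect already at smaller amounts and higher numbers for an effect only at larger amounts of compound:
Compound 1 `CNC(=N)Nc1nc(-c2ccc(OC)cc2)c(-c2ccc(OC)cc2)s1` gives 1.2 uM
Compound 2 `C/N=C(/NC)Nc1nc(-c2ccc(OC)cc2)c(-c2ccc(OC)cc2)s1` gives 2.4 uM
Compound 3 `COc1ccc(-c2nc(CN)sc2-c2ccc(OC)cc2)cc1` gives 7.7 uM

Of these three, compound 3 has the highest number, so it needs the largest amount for its effect. The next structure, compound 4 `COc1ccc(-c2nc(CNC(=O)C3=NNC(=O)CC3)sc2-c2ccc(OC)cc2)cc1`, differs from compound 3 by a group of 9 heavy atoms (5 carbon, 2 nitrogen, 2 oxygen; one six-membered non-aromatic ring with 2 hetero atoms) in place of a hydrogen atom, on an amine nitrogen. The entering group has no net charge.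

Going by the values given here, no measured step places a group on this amine nitrogen, so the evidence is only indirect. Among the compounds with values here, two steps bear on it, a 6.4-fold higher number from compound 1 to compound 3 (0.81 log units; beyond the scatter) and a 3.2-fold higher number from compound 2 to compound 3 (0.51 log units; beyond the scatter). In both, a smaller group on an aromatic carbon takes the place of a larger one, and the number rises modestly. Enlarging the group at that carbon might therefore lower the number again. A third step, a 2.0-fold higher number from compound 1 to compound 2 (0.30 log units; within the scatter), shows that a small enlargement elsewhere need not matter. The step expected in this assay is small, a 1.9-fold lower number from compound 3 to compound 4 (0.28 log units; within the scatter), and its direction is only a weak expectation. Compound 4 is estimated at 4 uM, with an expected range from 0.8 uM to 20 uM.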

Compound 4, concentration for half-maximal effect: 7.3 uM
Compound 4: middle estimate off by 1.8-fold (0.26 log units), on the low side; low and high end bracket the measured number.
By their numbers in this assay, from the lowest: compounds 1 and 2 (each within the scatter of the next); then compounds 4 and 3 (each within the scatter of the next).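

In this assay, the only step shown on this amine nitrogen is a 1.1-fold lower number from compound 3 to compound 4 (0.02 log units; within the scatter), so a group of 9 heavy atoms with a six-membered non-aromatic ring can sit here without a change that stands out from the scatter. The earlier steps shown here left it possible that a larger group on the aromatic carbon would bring the number down, but size alone does not sort these compounds: compound 4 carries the largest group of the series and gives 7.3 uM, while compound 1, with a smaller group, gives 1.2 uM. The data shown offer no measurement that explains why the number stays level when this group is added.

Only one group on this nitrogen is shown, so a single step cannot tell whether a small methyl or acetyl group, a longer chain or a carboxylic acid in the same place would also leave the number level. Going by these compounds, it also remains open whether the ring of the entering group matters, which an open-chain amide on this nitrogen could test.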